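Methoxy Added to the Anilino Ring of Compound 1

The source may hold more compounds than are shown below. What is called first, only, known or untested is meant among the compounds shown, and "the series" means these compounds.

Within the data shown here, compound 1 `Cc1nc(SCC(=O)Nc2nc(-c3ccc(Cl)cc3)cs2)n(Nc2ccccc2)c1C` is the only compound that gives a number in a functional assay on OVCAR-4 cells (Homo sapiens) for antiproliferative activity, read by sulforhodamine B assay, with a stated time of 48 h (a lower number here means a stronger inhibitor of growth, a higher number a weaker inhibitor of growth), where compound 1 gives 22100 nM. Compound 2 `Cc1ccc(Nn2c(SCC(=O)Nc3nc(-c4ccccc4)cs3)nc(C)c2C)cc1` gives in this assay > 100000 nM, which is a limit and not a number (the limit of > 100000 nM in this assay, at which 1 of the 2 values shown sits). Compound 3 `COc1ccc(Nn2c(SCC(=O)Nc3nc(-c4ccc(Cl)cc4)cs3)nc(C)c2C)cc1` differs from compound 1 by methoxy in place of hydrogen on an aromatic carbon. Among the measured compounds shown here, no step between measured compounds is known here, so the step is expected to be small, a 1.4-fold higher number from compound 1 to compound 3 (0.13 log units; within the scatter), within the usual scatter. Compound 3 is accordingly estimated at 30000 nM, in the range 8000 nM to 100000 nM.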

Compound 3, concentration for total growth inhibition: > 100000 nM
Compound 3: only a limit was reported (the forecaster's own chance of this, stated with the estimate: 30%); at least 3.3-fold (0.52 log units) between middle value and limit.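

The first step read at this place, para to a large group on the anilino ring, shows that methoxy in place of hydrogen does not leave the result unchanged: in this assay the change gives an at least 4.5-fold higher number from compound 1 to compound 3 (0.65 log units; beyond the scatter). Compound 3 gives > 100000 nM, which is a limit and not a number, so the step has a floor but no measured size. Most of the series now rests at that same limit: the limit of > 100000 nM in this assay, at which 2 of the 3 values shown sit.

From the compounds shown here alone, it remains open whether fluorine, a hydroxyl or an amine at this place on the core of compound 1 would keep its growth inhibition.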